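This account rests on a few compounds, and the source may have more. Where it says the series, first, only, none or still open, it means among the compounds named here.

Two compounds with a shared core, a nitro-bearing ring system carrying a carboxylic acid, differ only in the chain that links an aromatic nitrogen to a terminal benzene ring. Compound 1 `O=C(O)c1cn(CCCCc2ccccc2)c2ccc([N+](=O)[O-])cc12` gives 65.7% in an assay on cells (Oocyte) for inhibition of pannexin-1 (Mus musculus), read by voltage clamp, tested at 50 uM, in the presence of a further agent that is not named here; on this read-out higher numbers stand for more inhibition at the one concentration tested (going by the name of the read-out) and lower numbers for less inhibition. For the measured compounds named here, compound 2 `O=C(O)c1cn(CCCCCc2ccccc2)c2ccc([N+](=O)[O-])cc12` gives 32.3% in this assay, and on these two numbers compound 2 stands lowest, its only neighbour being compound 1, which sits a number 33.4 percentage points lower from compound 1 to compound 2 (beyond the scatter) apart in the other direction. Compound 3 `O=C(O)c1cn(CCCc2ccccc2)c2ccc([N+](=O)[O-])cc12` is the next member: phenyl in place of phenethyl on a saturated chain carbon, three bonds along the chain from an aromatic nitrogen. Going by the values given here, the one measured step that bears on this change is the lengthening of the chain a number 33.4 percentage points lower from compound 1 to compound 2 (beyond the scatter), a large loss when the chain grew by one carbon. Compound 3 shortens the chain instead, so the expectation is that the inhibition recovers rather than falls further, although with a single step no one can say whether a chain shorter than that of compound 1 is as good as it. The expected step is a number 22.7 percentage points higher from compound 2 to compound 3 (beyond the scatter). Compound 3 is therefore estimated at 55%, within a range from 25% to 85%.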

Compound 3, a percentage reported as inhibition, at one concentration (the size of the read-out at that concentration, not a potency): 71%
Compound 3: the middle estimate sits 16 percentage points below what was measured; the measured number falls inside the stated range.
By their numbers in this assay, from the lowest: compound 2; then compounds 1 and 3 (each within the scatter of the next).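

Shortening the chain, with phenyl in place of phenethyl on a saturated chain carbon, three bonds along the chain from an aromatic nitrogen, gives a number 38.7 percentage points higher from compound 2 to compound 3 (beyond the scatter) in this assay, so the low reading of compound 2 does not carry over to every chain on the shared core. Going from the chain of compound 1 to the shorter one gives a number 5.3 percentage points higher from compound 1 to compound 3 (within the scatter), which means the two compounds cannot be told apart here, and among these three compounds only the longest chain, in compound 2, stands out, with a clear loss of inhibition. Nothing available explains why the number for that longest chain is lower, or why the two shorter chains read alike.

From the compounds shown here alone, whether a still shorter chain, an ether oxygen within the chain, or a fluorine on the terminal benzene ring would keep this level of inhibition remains open. These readings also come from a single concentration, so they give only the size of the effect at that concentration, and compounds that match there could still differ at other concentrations.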